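Swapping a dimethylamino for a hydroxy on a second core

The source may hold more compounds than are shown below. What is called first, only, known or untested is meant among the compounds shown, and "the series" means these compounds.

Of the compounds shown here, three have been measured in a functional assay on A549 cells (Homo sapiens) for antiproliferative activity, read by MTT assay, with a stated time of 48 h; on this read-out lower numbers stand for stronger inhibition and higher numbers for weaker inhibition. Compound 1 `COc1ccc(C(=O)c2ccc(OC)c3c2OC(C)(C)C=C3)c(NC(=O)CO)c1` gives 80 nM. Compound 2 `COc1ccc(C(=O)c2ccc(OC)c3c2OC(C)(C)C=C3)c(NC(=O)CN(C)C)c1` gives 890 nM. Compound 3 `C=C(c1cc(OC)c(OC)c(OC)c1)c1ccc(OC)c(O)c1NC(=O)CN(C)C` gives 50 nM. Compound 2 and compound 1 share a core and differ only by hydroxy in place of dimethylamino on a saturated chain carbon bound to a carbonyl carbon; this change made an 11-fold lower number from compound 2 to compound 1 (1.05 log units; beyond the scatter). Compound 3 is built on a different core, and how that core differs from the core of compound 2 is not broken down here; the two values simply show compound 3 at the lower number and compound 2 at the higher one.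

Compound 4 `C=C(c1cc(OC)c(OC)c(OC)c1)c1ccc(OC)c(O)c1NC(=O)CO` has not yet been measured. It stands to compound 3 as compound 1 stands to compound 2, differing by hydroxy in place of dimethylamino on a saturated chain carbon bound to a carbonyl carbon. The place of the change is the same in both pairs, so the same change is made, but on another core. Going by the values given here, because the step of an 11-fold lower number from compound 2 to compound 1 (1.05 log units; beyond the scatter) was large on the first core, a step in the same direction is expected for compound 4 in this assay, somewhat smaller given that only one such pair is available, estimated as a 4.2-fold lower number from compound 3 to compound 4 (0.62 log units; beyond the scatter). Compound 4 is therefore expected to give about 12 nM, most likely between 3 nM and 50 nM.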

Compound 4, half-maximal inhibitory concentration: 10 nM
Compound 4: the middle estimate sits 1.2-fold (0.08 log units) above what was measured, within the range that was stated.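

In this assay, putting hydroxy in place of dimethylamino on the second core gave a 5.0-fold lower number from compound 3 to compound 4 (0.70 log units; beyond the scatter), the same direction as on the first core. The two steps cannot be told apart in size, so on these two cores the change carried over with an effect that is the same as far as the data can show: the same change on two cores in this assay, an 11-fold lower number (1.05 log units; beyond the scatter) from compound 2 to compound 1 and a 5.0-fold lower number (0.70 log units; beyond the scatter) from compound 3 to compound 4, 2.2-fold (0.35 log units) apart, within the scatter of two such steps. Going by these compounds alone, this is only two matched pairs in one assay, so it does not establish a rule for other cores, and it does not explain why the number falls with this change.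

The compounds shown leave open whether hydroxy is special at this place on the chain, or whether a methoxy, a primary amine or a carboxylic acid there would give similar numbers. They also leave open whether a longer chain carrying the hydroxy would keep the lower number seen with compound 4 and compound 1.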